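The source may hold more compounds than are shown below. What is called first, only, known or untested is meant among the compounds shown, and "the series" means these compounds.

Four compounds share a common core, all tested in a functional assay on A549 cells (Homo sapiens) for antiproliferative activity, with a stated time of 72 h; a lower number here means a stronger inhibitor, a higher number a weaker inhibitor. Compound 1 `Cc1ccc(C2=NN(c3nc(-c4ccccc4)c(C#N)c(=O)n3C)C(c3ccc(F)cc3)C2)cc1` gives 2000 nM. Compound 3 `Cc1ccc(C2=NN(c3nc(-c4ccc(Cl)cc4)c(C#N)c(=O)n3C)C(c3ccc(F)cc3)C2)cc1` carries chloro in place of hydrogen on an aromatic carbon relative to compound 1, and compound 3 gives 35600 nM. That single change made an 18-fold higher number from compound 1 to compound 3 (1.25 log units; beyond the scatter). Compound 2 `Cn1c(N2N=C(c3ccccc3)CC2c2ccccc2)nc(-c2ccc(Cl)cc2)c(C#N)c1=O` has a different core from compound 1; the difference between the two cores is not broken down here. In this assay compound 2 gives 28100 nM, a number that lies near the value of compound 3 and well apart from that of compound 1.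

Compound 4 `Cn1c(N2N=C(c3ccc(Cl)cc3)CC2c2ccccc2)nc(-c2ccc(Cl)cc2)c(C#N)c1=O` has not yet been measured. It stands to compound 2 as compound 3 stands to compound 1: it carries chloro in place of hydrogen on an aromatic carbon, and the place of that change is the same in both pairs, so it is the same change made twice among these four compounds. Among the compounds with values here, the expected step from compound 2 to compound 4 is a 4.3-fold higher number from compound 2 to compound 4 (0.63 log units; beyond the scatter), placed beside the measured one, and this rests on the single earlier step of an 18-fold higher number from compound 1 to compound 3 (1.25 log units; beyond the scatter) seen between compound 1 and compound 3, with the caution that compound 2 already starts from a high number and the same change has been seen only once. Compound 4 is therefore expected to give about 120000 nM, somewhere between 30000 nM and 500000 nM, before the measurement is known.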

Compound 4, half-maximal inhibitory concentration: 43900 nM
Estimate against measurement, compound 4: 2.7-fold (0.44 log units) above, and the stated range covers the measured number.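

Putting chloro in place of hydrogen gave a 1.6-fold higher number from compound 2 to compound 4 (0.19 log units; within the scatter) in this assay, so the large rise seen on the core of compound 1 did not appear on this second core. Set side by side, the two steps clearly differ: the same change on two cores in this assay, an 18-fold higher number (1.25 log units; beyond the scatter) from compound 1 to compound 3 and a 1.6-fold higher number (0.19 log units; within the scatter) from compound 2 to compound 4, 11-fold (1.06 log units) apart, beyond the scatter of two such steps. Within the data shown here, this shows that, in this series, the step measured on one core cannot be carried to the other as a fixed amount, so a prediction made that way may be well off; it does not show which feature of the two cores separates the results, and with only one pair on each core it gives no general rule.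

The compounds shown leave open whether a different group in place of chloro, such as methoxy or an amine, would also give steps of unequal size on the two cores. They also leave open how the same chloro change would behave on further cores, and so whether the large step or the small one is the more usual result across this series.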